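Halogen at the aromatic ring: fluoro analogue of compound 3

The compounds below may be only part of what the source reports. "The series", "measured", "known", "first", "only" and "open" are said of these compounds alone.

In a functional assay on the whole organism for inhibition, with Mythimna separata as the target, with a stated time of 5 days (on this read-out lower numbers stand for an effect already at smaller amounts and higher numbers for an effect only at larger amounts of compound), compound 3 `CC(C)(C)n1ncc(OCc2nnc(-c3ccccc3)s2)c(Cl)c1=O` gives 200000 nM; compound 1 `CC(C)(C)n1ncc(OCc2nnc(-c3ccc(Cl)cc3Cl)s2)c(Cl)c1=O` gives 62200 nM and compound 2 `CC(C)(C)n1ncc(OCc2nnc(-c3ccc(Cl)cc3)s2)c(Cl)c1=O` gives 106000 nM. Compound 3 thus stands at the highest number of the three, with a 3.2-fold higher number from compound 1 to compound 3 (0.51 log units; beyond the scatter) and a 1.9-fold higher number from compound 2 to compound 3 (0.28 log units; within the scatter). Compound 4 `CC(C)(C)n1ncc(OCc2nnc(-c3ccc(F)cc3)s2)c(Cl)c1=O` differs from compound 3 by fluoro in place of hydrogen on an aromatic carbon, placed on an aromatic carbon of a six-membered aromatic ring of carbon only, para to a large group. The reverse of the step of a 1.9-fold higher number from compound 2 to compound 3 (0.28 log units; within the scatter) is the nearest comparison, chloro rather than fluoro at that carbon. A small step is expected for compound 4, downward, of the size a 1.3-fold lower number from compound 3 to compound 4 (0.12 log units; within the scatter). The estimate for compound 4 in this assay is 150000 nM, with a range of 80000 nM to 300000 nM.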

Compound 4, half-maximal effective concentration: 21500 nM
The estimate for compound 4 lay 7.0-fold (0.84 log units) above the measured number, and the stated range ends above it.
By their numbers in this assay, from the lowest: compound 4; then compounds 1, 2 and 3 (each within the scatter of the next, the first and the last beyond it).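

Notes: in this assay this carbon proves sensitive to which halogen it carries, since fluoro in place of hydrogen gives a 9.3-fold lower number from compound 3 to compound 4 (0.97 log units; beyond the scatter) while chloro stayed within the scatter of hydrogen. The halogens are not interchangeable here, with a 4.9-fold lower number from compound 2 to compound 4 (0.69 log units; beyond the scatter) on going from chloro to fluoro. The single fluoro also outperforms the two chloro groups, with a 2.9-fold lower number from compound 1 to compound 4 (0.46 log units; beyond the scatter) for 4-fluorophenyl in place of 2,4-dichlorophenyl.

Nothing available explains why fluoro and chloro part here. Still open, from the compounds shown here alone, is how methoxy, trifluoromethyl or nitrile would behave at this carbon.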